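A few compounds are considered here, and "the series" means these few. Any claim that something is new, unique, unknown or untested is made for them only; others in the source may bear on it.

Measured so far in an assay for inhibition of very long chain fatty acid elongase 6 (Homo sapiens); a lower number here means a stronger inhibitor, a higher number a weaker inhibitor:

Compound 1 `O=C1Nc2ccc(-n3cncn3)cc2C(CNC(=O)c2ccc(F)cc2)(C(F)(F)F)O1`: 572 nM
Compound 2 `O=C(Nc1ccc(F)cc1)OCC1(C2CC2)OC(=O)Nc2ccc(Cl)cc21`: 1410 nM
Compound 3 `O=C1Nc2ccc(Cl)cc2C(CNC(=O)c2cccc(F)c2)(C(F)(F)F)O1`: 261 nM

Compound 3 has the lowest number of the three; compound 1 sits higher by a margin beyond the scatter, and compound 2 higher still. Compound 4 `Cc1cccc(C(=O)NCC2(C(F)(F)F)OC(=O)Nc3ccc(Cl)cc32)c1` is the untested partner of compound 3: methyl in place of fluoro on an aromatic carbon, (methyl in place of fluoro on an aromatic carbon). For the measured compounds named here, no measured pair shows this change, so there is no step to lean on. On the numbers in hand the change is expected to stay small, with the step from compound 3 to compound 4 estimated as a 1.1-fold higher number from compound 3 to compound 4 (0.06 log units; within the scatter), which is not beyond the scatter. Compound 4 is therefore expected at 300 nM, within 130 nM to 700 nM.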

Compound 4, half-maximal inhibitory concentration: 437 nM
Estimate against measurement, compound 4: 1.5-fold (0.16 log units) below; measured number inside the range.
By their numbers in this assay, from the lowest: compounds 3, 4 and 1 (each within the scatter of the next, the first and the last beyond it); then compound 2.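

For the compounds shown here, the first single-change pair reads in this assay: methyl in place of fluoro on an aromatic carbon, meta to a large group, gives a 1.7-fold higher number from compound 3 to compound 4 (0.22 log units; within the scatter) and so lies within the scatter. Going by these compounds alone, at this position, 3-fluorophenyl and 3-methylphenyl are not told apart by this assay, which the earlier compounds, all differing in more than one place, could not show. No supporting measurement bears on the reason for this result.

Still open, as far as these compounds go, is whether an amine, a carboxylic acid or a longer chain at this carbon would give a step beyond the scatter. Also open, from the compounds shown here alone, is whether the same exchange behaves alike on the core of compound 1.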